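The source may report more compounds than this note shows. Statements on the series, on what has been measured and on what is new or still open speak of the compounds shown alone.

Two compounds have been measured in a functional assay on SK-MEL-28 cells (Homo sapiens) for antiproliferative activity, with a stated time of 48 h; a higher number here means a weaker inhibitor of growth, a lower number a stronger inhibitor of growth:
compound 1 `Cc1cc(O)c(C2=NN(c3ccc(S(N)(=O)=O)cc3)C(c3ccccc3Cl)C2)cc1Cl`, 3390 nM
compound 2 `Cc1cc(O)c(C2=NN(c3ccc(S(N)(=O)=O)cc3)C(/C=C/c3ccccc3)C2)cc1Cl`, 10900 nM

Compound 2 gives the higher of these two numbers, so it is the weaker growth inhibitor of the pair. For the measured compounds named here, the only measured step, a 3.2-fold higher number from compound 1 to compound 2 (0.51 log units; beyond the scatter), exchanged an aromatic ring on a saturated ring carbon for a 2-phenylethenyl group, and the number rose by a modest amount. Compound 3 `COc1ccc(C2CC(c3cc(Cl)c(C)cc3O)=NN2c2ccc(S(N)(=O)=O)cc2)cc1OC` goes the other way: 3,4-dimethoxyphenyl in place of 2-phenylethenyl on a saturated ring carbon. An aromatic ring on that carbon went with the lower number, because compound 1 gives 3390 nM while compound 2 gives 10900 nM. The step for compound 3 is therefore expected to be a fall in this assay, roughly undoing the earlier rise, and the estimated step is a 2.4-fold lower number from compound 2 to compound 3 (0.38 log units; beyond the scatter). Compound 3 is expected to give about 4500 nM, with a likely range from 1500 nM to 13000 nM.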

Compound 3, concentration for 50% growth inhibition: 4290 nM
The estimate for compound 3 lay 1.0-fold (0.02 log units) above the measured number; low and high end bracket the measured number.
By their numbers in this assay, from the lowest: compounds 1 and 3 (each within the scatter of the next); then compound 2.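

In this assay, placing 3,4-dimethoxyphenyl where 2-phenylethenyl stood gives a 2.5-fold lower number from compound 2 to compound 3 (0.40 log units; beyond the scatter), so a second substituted phenyl group on this saturated ring carbon also falls on the side of the lower number. Exchanging 2-chlorophenyl for 3,4-dimethoxyphenyl gives a 1.3-fold higher number from compound 1 to compound 3 (0.10 log units; within the scatter), so these two groups cannot be told apart in this assay, although the methoxy groups of one are absent from the other. Nothing measured here explains the gap between these phenyl groups and 2-phenylethenyl.

As far as these compounds go, whether an aromatic ring on this carbon is what matters remains open, and a cyclohexyl ring, a plain ethyl chain or a phenyl ring bearing an amine would help to test it. Also open, from the compounds shown here alone, is whether the same ranking holds when the 5-chloro-2-hydroxy-4-methylphenyl group or the 4-sulfamoylphenyl group is changed.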